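Changing one aryl group on a weak growth inhibitor

A few compounds are considered here, and "the series" means these few. Any claim that something is new, unique, unknown or untested is made for them only; others in the source may bear on it.

Among the compounds with values here, in a functional assay on DU-145 cells (Homo sapiens) for inhibition, read by trypan blue exclusion, with a stated time of 96 h (a higher number here means a weaker inhibitor of growth, a lower number a stronger inhibitor of growth), compound 1 (`CN(C)c1ccc(/C=C(/SCc2ccc(F)cc2)C(=O)c2ccc(Br)cc2)cc1`) gives 50000 nM as the higher of the two numbers so far. Compound 2 (`CN(C)c1ccc(/C=C(/SCc2ccc(F)cc2)C(=O)c2ccc(C(=O)O)cc2)cc1`) gives 10000 nM with carboxy in place of bromo on an aromatic carbon. Within the data shown here, that is the only measured step, a 5.0-fold lower number from compound 1 to compound 2 (0.70 log units; beyond the scatter) in size, and it lies at another place in the molecule.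

Compound 3 (`Cc1ccc(C)c(/C=C(/SCc2ccc(F)cc2)C(=O)c2ccc(Br)cc2)c1`) has 2,5-dimethylphenyl in place of 4-(dimethylamino)phenyl on a double-bonded chain carbon bound to a double-bonded chain carbon. Among the measured compounds shown here, no measured step tests this swap, so the evidence is thin. Compound 1 at 50000 nM sits at the top of the numbers seen, so a modest fall looks likelier than a rise. In this assay the expected change is a 2.5-fold lower number from compound 1 to compound 3 (0.40 log units; beyond the scatter) as a rough estimate. Compound 3 is expected at 20000 nM with an estimated range of 5000 nM to 60000 nM around it.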

Compound 3, concentration for 50% growth inhibition: 1000 nM
Estimate against measurement, compound 3: 20-fold (1.30 log units) above; the whole stated range lies above it.
By their numbers in this assay, from the lowest: compound 3; then compound 2; then compound 1.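

In this assay, the aryl group on a double-bonded chain carbon bound to a double-bonded chain carbon proves to be a sensitive position: 2,5-dimethylphenyl in place of 4-(dimethylamino)phenyl gives a 50-fold lower number from compound 1 to compound 3 (1.70 log units; beyond the scatter). This large step contrasts with the modest 5.0-fold lower number from compound 1 to compound 2 (0.70 log units; beyond the scatter) at the other aryl group. No measurement shown here explains why the step is so large.

As far as these compounds go, the swap removes the nitrogen and adds two methyl groups, so it remains open which of these changes matters; an unsubstituted phenyl or a 4-methylphenyl group at this position would help to separate them. From the compounds shown here alone, it is also open whether the carboxy group of compound 2 would lower the number further if combined with the 2,5-dimethylphenyl group of compound 3.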